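Methyl for Nitrile on the Pyrazole of a Glucagon Antagonist

This account rests on a few compounds, and the source may have more. Where it says the series, first, only, none or still open, it means among the compounds named here.

Compound 1 `CCCC(Nc1cc(C)c(-n2cc(C(F)(F)F)cn2)c(C)c1)c1ccc(C(=O)NCCC(=O)O)cc1` gives 1400 nM in a functional assay on cells for antagonist activity at Glucagon receptor (Homo sapiens), read by cAMP accumulation, in the presence of a further agent that is not named here; a lower number here means a stronger inhibitor, a higher number a weaker inhibitor.
Compound 2 `CCCC(Oc1ccc(-n2cc(C#N)cn2)cc1)c1ccc(C(=O)NCCC(=O)O)cc1` gives only a limit of the assay, > 50000 nM, in this assay.
Compound 3 `CCCC(Oc1ccc(-n2cc(C(F)(F)F)cn2)nc1)c1ccc(C(=O)NCCC(=O)O)cc1` gives 3700 nM in this assay.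

Compound 2 stands at the weak end of these numbers, where it sits at the limit of > 50000 nM in this assay, at which 1 of the 3 values shown sits. Compound 4 `CCCC(Oc1ccc(-n2cc(C)cn2)cc1)c1ccc(C(=O)NCCC(=O)O)cc1` differs from compound 2 in one place: methyl in place of cyano on an aromatic carbon. For the measured compounds named here, no two measured compounds differ in one place only, so no measured step guides the expectation. Both compounds that carry trifluoromethyl rather than cyano on the pyrazole reach measurable numbers, and the expected step in this assay is therefore a gain, beyond the usual scatter, reading an at least 3.3-fold lower number from compound 2 to compound 4 (0.52 log units; beyond the scatter). Compound 4 is estimated at 15000 nM, within 4000 nM to 60000 nM.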

Compound 4, antagonist equilibrium constant: 11000 nM
The estimate for compound 4 lay 1.4-fold (0.13 log units) above the measured number, within the range that was stated.
By their numbers in this assay, from the lowest: compound 1; then compound 3; then compound 4. At a limit, above all of these: compound 2.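

For the compounds shown here, changing cyano to methyl on the pyrazole gives an at least 4.5-fold lower number from compound 2 to compound 4 (0.65 log units; beyond the scatter), the first comparison here between compounds that differ in one place, and it shows that the group at this position matters in this assay. Compound 2 stands at a limit of the assay, not at a measured number, so the step has a lower bound but no exact size: the limit of > 50000 nM in this assay, at which 1 of the 4 values shown sits.

The compounds shown leave open how an ethyl group, a methoxy group or an amine would read at this position. They also leave open how trifluoromethyl would read there on the core of compound 4.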